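This account rests on a few compounds, and the source may have more. Where it says the series, first, only, none or still open, it means among the compounds named here.

In an ADME assay on MDCK cells (Canis lupus familiaris) for cytotoxicity, read by MTT assay, with a stated time of 24 h (a lower number here means that less compound is tolerated, a higher number that more compound is tolerated), compound 3 (`O=[N+]([O-])c1ccc(S(=O)(=O)NCc2csc3ccccc23)cc1`) gives > 191000 nM as its reading, which is a limit and not a number. It is the only reading of this kind in the series (the limit of > 191000 nM in this assay, at which 1 of the 3 values shown sits). Compound 4 (`O=S(=O)(NCc1csc2ccccc12)c1ccc(F)cc1`) has fluoro in place of nitro on an aromatic carbon, para to a large group (fluoro in place of nitro on an aromatic carbon). Within the data shown here, no measured step covers the loss of nitro. The nearest evidence comes from a different core: compound 1 (`Cc1cc(CNS(=O)(=O)c2ccc(F)cc2)c(C)o1`) gives 138000 nM in this assay and compound 2 (`Cc1cc(CNS(=O)(=O)c2ccc(Cl)cc2)c(C)o1`) gives 55700 nM on the same scale. That pair shows a 2.5-fold lower number from compound 1 to compound 2 (0.39 log units; beyond the scatter) and so bears only on a change between halogens. With fluoro compound 1 at 138000 nM as the only anchor, a modest move toward a lower number is expected for compound 4, with wide uncertainty. The expected size is an at least 1.5-fold lower number from compound 3 to compound 4 (0.20 log units; that floor lies within the scatter) and remains a rough estimate against a limit. For compound 4 the estimated value is 120000 nM (expected range 45000 nM to 300000 nM).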

Compound 4, half-maximal cytotoxic concentration: 98600 nM
Compound 4: middle estimate off by 1.2-fold (0.09 log units), on the high side; measured number inside the range.
By their numbers in this assay, from the lowest: compounds 2, 4 and 1 (each within the scatter of the next, the first and the last beyond it). At a limit, above all of these: compound 3.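

In this assay, fluoro in place of nitro on an aromatic carbon, para to a large group, gives an at least 1.9-fold lower number from compound 3 to compound 4 (0.28 log units; that floor lies within the scatter). Compound 4 gives 98600 nM, so this core now has a measured number at this position, whereas the earlier pair spoke only to a change between halogens on a different core. The reading for compound 3 is a limit and not a number, so this step has only a floor and the true size of the change at this position stays unfixed: the limit of > 191000 nM in this assay, at which 1 of the 4 values shown sits.

Still open, going by these compounds, is whether chloro at this position on the core of compound 4 would repeat a 2.5-fold lower number from compound 1 to compound 2 (0.39 log units; beyond the scatter). Also open, on these data alone, is where the reading on this core would fall with an amine or a carboxylic acid at this position.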